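Urea terminus change on the shared core: compound 4

The compounds below may be only part of what the source reports. "The series", "measured", "known", "first", "only" and "open" are said of these compounds alone.

Compound 1 `CNC(=O)Nc1ccc(-c2nc(N3CC4CCC(C3)O4)c3sc(CN4CCN(S(C)(=O)=O)CC4)cc3n2)cc1` gives 120 nM in a functional assay on LNCaP cells (Homo sapiens) for cytotoxicity (on this read-out lower numbers stand for stronger inhibition and higher numbers for weaker inhibition), the second highest of the three numbers. Compound 2 `CNC(=O)Nc1ccc(-c2nc(N3CC4CCC(C3)O4)c3sccc3n2)cc1` gives 85 nM in this assay, and a 1.4-fold lower number from compound 1 to compound 2 (0.15 log units; within the scatter). Compound 3 `CN1CCN(Cc2cc3nc(-c4ccc(NC(=O)NC5CC5)cc4)nc(N4CC5CCC(C4)O5)c3s2)CC1` gives 400 nM in this assay; it differs from compound 1 in two places at once, so no single step can be read from that pair. Compound 4 `CS(=O)(=O)N1CCN(Cc2cc3nc(-c4ccc(NC(=O)Nc5ccncc5)cc4)nc(N4CC5CCC(C4)O5)c3s2)CC1` carries pyridin-4-yl in place of methyl on an amide-type nitrogen. Going by the values given here, no measured step touches that amide-type nitrogen; the only measured step concerns a different part of the molecule. Among the compounds with values here, compound 3, the one other compound altered at that nitrogen, gives 400 nM in this assay. A modest rise is expected in this assay: a 1.7-fold higher number from compound 1 to compound 4 (0.22 log units; within the scatter). Compound 4 is estimated at 200 nM, with a range of 60 nM to 700 nM.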

Compound 4, half-maximal inhibitory concentration: 120 nM
Compound 4: the middle estimate sits 1.7-fold (0.22 log units) above what was measured; measured number inside the range.
By their numbers in this assay, from the lowest: compounds 2, 1 and 4 (each within the scatter of the next); then compound 3.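

Pyridin-4-yl in place of methyl on the amide-type nitrogen gives no change at the digits printed from compound 1 to compound 4 (within the scatter) in this assay, so a single methyl and a six-membered aromatic ring with one hetero atom read alike at this nitrogen on the shared core. The earlier compounds shown here gave no clean single-place reading of this position. No supporting data bear on why the two groups read alike.

Open, on these data alone, is whether the ring nitrogen of pyridin-4-yl matters, which a phenyl group at the same place would address. Also open, as far as these compounds go, is how an amine or a carboxylic acid on a longer chain would read there.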